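Trading chloro for hydrogen on compound 2

This account rests on a few compounds, and the source may have more. Where it says the series, first, only, none or still open, it means among the compounds named here.

Among the measured compounds shown here, in an ADME assay on MT4 cells (Homo sapiens) for cytotoxicity, read by MTT assay (a lower number here means that less compound is tolerated, a higher number that more compound is tolerated), compound 1 (`Cc1cnc(Nc2ccc(C#N)cc2)nc1C(C)c1c(F)cccc1F`) gives 71400 nM as its only firm number. Compound 2 (`Cc1c(Cl)nc(Nc2ccc(C#N)cc2)nc1Cc1c(F)cccc1F`) reads > 2690 nM in this assay and this is a limit, not a number. Compared with compound 2, compound 3 (`Cc1cnc(Nc2ccc(C#N)cc2)nc1Cc1c(F)cccc1F`) has hydrogen in place of chloro on an aromatic carbon. For the measured compounds named here, no measured step isolates this change. Going by the values given here, compound 1 also has no chloro and its 71400 nM is the only guide, so a rise in tolerated concentration is expected (a step that the limit leaves unreadable from compound 2 to compound 3). For compound 3 the expected value is 30000 nM within an estimated range from 6000 nM to 100000 nM.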

Compound 3, half-maximal cytotoxic concentration: > 74300 nM
Compound 3: no number, only a limit; the forecaster's own chance of this, stated with the estimate: 35%; at least 2.4-fold (0.39 log units) between middle value and limit.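

In this assay compound 3 reads > 74300 nM, which is a limit and not a number. Compound 2 also gives only a limit, so the step for hydrogen in place of chloro on this aromatic carbon, next to the ring nitrogen, cannot be read. Hydrogen in place of methyl on the saturated chain carbon bound to two aromatic carbons gives an at least 1.0-fold higher number from compound 1 to compound 3 (0.01 log units; that floor lies within the scatter), so only a floor is known for that change.

Going by these compounds, how far compound 3 lies beyond its limit remains open. So does how an amine or a methoxy group on this aromatic carbon would read in this assay.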